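Phenyl in place of thiophen-2-yl at the aromatic carbon

The source may hold more compounds than are shown below. What is called first, only, known or untested is meant among the compounds shown, and "the series" means these compounds.

Measured so far in a functional assay on HeLa S3 cells (Homo sapiens) for antiproliferative activity, read by XTT assay, with a stated time of 72 h (a higher number here means a weaker inhibitor, a lower number a stronger inhibitor), for three compounds:
- Compound 1 `O=c1[nH]cnc2c1c(-c1ccccc1)cn2[C@@H]1O[C@H](CO)[C@@H](O)[C@H]1O` gives > 20000 nM as a limit
- Compound 2 `Nc1nc2c(c(-c3ccoc3)cn2[C@@H]2O[C@H](CO)[C@@H](O)[C@H]2O)c(=O)[nH]1` gives 10700 nM as a measured number
- Compound 3 `Nc1nc2c(c(-c3cccs3)cn2[C@@H]2O[C@H](CO)[C@@H](O)[C@H]2O)c(=O)[nH]1` gives > 20000 nM as a limit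

Compound 3 stands at the limit of > 20000 nM in this assay, at which 2 of the 3 values shown sit, and so has no exact number. Compound 4 `Nc1nc2c(c(-c3ccccc3)cn2[C@@H]2O[C@H](CO)[C@@H](O)[C@H]2O)c(=O)[nH]1` carries phenyl in place of thiophen-2-yl on an aromatic carbon on an aromatic carbon of the same core.

For the measured compounds named here, the one measured step at this carbon is an at least 1.8-fold higher number from compound 2 to compound 3 (0.27 log units; that floor lies within the scatter) and it swaps furan-3-yl for thiophen-2-yl. On these data alone, its true size stays unknown, as one end of it is only a limit. Compound 1 also carries phenyl, on a different core, and it stays at > 20000 nM as a limit.

No step beyond the scatter is therefore expected in this assay in either direction. The estimated size is a number no higher from compound 3 to compound 4 (the limit leaves the size open) and no more. For compound 4 the expected value is 20000 nM with an estimated range from 8000 nM to 40000 nM and a fair chance of only a limit.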

Compound 4, half-maximal inhibitory concentration: > 20000 nM
Compound 4: a limit, no number (the forecaster's own chance of this, stated with the estimate: 65%); the middle value lies on the limit itself.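

Phenyl at this aromatic carbon leaves the compound without an exact number in this assay, so a six-membered aromatic ring of carbon only does no better here than thiophen-2-yl, as far as a limit can show. The result gives an at least 1.8-fold higher number from compound 2 to compound 4 (0.27 log units; that floor lies within the scatter), so furan-3-yl cannot be said to outperform phenyl here. The steps to compound 4 from compound 3 and from compound 1 cannot be read, as both ends of each are limits, and this is because most results in the series now share one ceiling: the limit of > 20000 nM in this assay, at which 3 of the 4 values shown sit.

On these data alone, what the amino group adds to the core therefore remains unknown. Also open, as far as these compounds go, is whether a group of a different kind at this carbon, such as methyl or an aminomethyl chain, would give a stronger, exactly measurable result.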